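The source may hold more compounds than are shown below. What is called first, only, known or untested is meant among the compounds shown, and "the series" means these compounds.

Compound 3 `Nc1ncnc2c1nc(O)n2Cc1ccccc1` gives 10 uM in a functional assay (spleen, spleen) for activation, with Mus musculus as the target; on this read-out higher numbers stand for an effect only at larger amounts of compound and lower numbers for an effect already at smaller amounts. It stands level with compound 1 `Cc1ccc(Cn2c(O)nc3c(N)ncnc32)cc1`, which gives 10 uM; the step of no change at the digits printed from compound 1 to compound 3 (within the scatter) shows the two together as the highest pair of three numbers. Compound 2 `CCCCCNc1nc(N)c2nc(O)n(Cc3ccccc3)c2n1` gives 0.1 uM, and the step of a 100-fold higher number from compound 2 to compound 3 (2.00 log units; beyond the scatter) is large.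

Compound 4 `Nc1ncnc2c1nc(O)n2Cc1ccc(F)cc1` differs from compound 3 in one place: fluoro in place of hydrogen on an aromatic carbon. For the measured compounds named here, only the step from compound 1 to compound 3 touches this same ring, since no change at the digits printed from compound 1 to compound 3 (within the scatter) swapped a small group there and stayed within the scatter. The step from compound 2 to compound 3 concerns a different part of the shared core. So for compound 4 the expected step is no change at the digits printed from compound 3 to compound 4 (within the scatter), none beyond the scatter, and compound 4 is estimated at 10 uM, between 3 uM and 30 uM.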

Compound 4, minimum effective concentration: 10 uM
Compound 4: the middle estimate sits on the measured number at the digits printed; the measured number falls inside the stated range.
By their numbers in this assay, from the lowest: compound 2; then compounds 1, 3 and 4 (each within the scatter of the next).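

In this assay, three groups on this aromatic carbon now read alike: fluoro in place of hydrogen gives no change at the digits printed from compound 3 to compound 4 (within the scatter), and fluoro in place of methyl gives no change at the digits printed from compound 1 to compound 4 (within the scatter). So this place, para to a large group, has so far shown no step beyond the scatter, for a change in either direction of the series. Nothing measured here explains this sameness. As far as these compounds go, whether an amine, a carboxylic acid or a longer chain at this place would read the same stays open, as does whether fluoro would leave the number of compound 2 unmoved.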